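The compounds below may be only part of what the source reports. "The series", "measured", "known", "first", "only" and "open" are said of these compounds alone.

Compound 1 `Cc1noc(C)c1-c1ccc(-c2nc(C)c([C@H](OC(C)(C)C)C(=O)O)c(-c3ccc(Cl)cc3)c2C)cc1`: 2.67 h
Compound 2 `Cc1ccc(-c2nc(C)c([C@H](OC(C)(C)C)C(=O)O)c(-c3ccc4c(c3)CCCO4)c2C)cc1C`: 1.83 h

In an ADME assay (liver) for metabolic stability, with Liver microsome (Rattus norvegicus) as the target, using microsomes (a higher number here means that the compound lasts longer, a lower number that the compound disappears faster), compound 1 gives 2.67 h and compound 2 gives 1.83 h, so the two numbers lie within the usual scatter of each other. Compound 3 `Cc1ccc(-c2nc(C)c([C@H](OC(C)(C)C)C(=O)O)c(-c3ccc4c(c3Cl)NCCO4)c2C)cc1C` has not yet been measured. It keeps the rest of compound 2 and changes one group on an aromatic carbon, opposite the ring nitrogen: a group of 11 heavy atoms (8 carbon, 1 nitrogen, 1 oxygen, 1 chlorine; one six-membered non-aromatic ring with 2 hetero atoms, one six-membered aromatic ring of carbon only) in place of a group of 10 heavy atoms (9 carbon, 1 oxygen; one six-membered non-aromatic ring with 1 hetero atom, one six-membered aromatic ring of carbon only), on an aromatic carbon. The group that enters adds chlorine and nitrogen. The two measured compounds differ in more than one place, so neither shows directly what this exchange does. Going by the values given here, with no measured step as a guide, no change beyond the scatter is expected, and no direction can be favoured. The expected step of a 1.1-fold higher number from compound 2 to compound 3 (0.04 log units; within the scatter) is therefore small. The estimate for compound 3 is 2 h, with an expected range from 0.9 h to 4.5 h.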

Compound 3, half-life: 0.933 h
Compound 3: middle estimate off by 2.1-fold (0.33 log units), on the high side, and the stated range covers the measured number.
By their numbers in this assay, from the lowest: compounds 3, 2 and 1 (each within the scatter of the next, the first and the last beyond it).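

Going by these compounds alone, this is the first step that can be read at this position, the aromatic carbon opposite the ring nitrogen: in this assay, the exchange gives a 2.0-fold lower number from compound 2 to compound 3 (0.29 log units; within the scatter). So a group that adds chlorine and nitrogen, and with them a hydrogen-bond donor, does not move the half-life beyond what repeated measurements would show, which compounds 1 and 2 could not tell, as they differ in more than one place. Nothing measured here explains the number, and no cause can be given.

From the compounds shown here alone, the exchange brings in the chlorine and the ring nitrogen together, so what each does alone remains open. Also open, going by these compounds, is how a fluorine atom in place of the chlorine, or an amide in place of the ring amine, would behave in this assay.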